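The source may report more compounds than this note shows. Statements on the series, on what has been measured and on what is new or still open speak of the compounds shown alone.

Compound 1 `NC1=NC2(CCSCC2)N(OCCCOc2ccc(Cl)c(Cl)c2)C(N)=N1` and compound 2 `NC1=NC2(CCSCC2)N(OCCCOc2cc(Cl)c(Cl)cc2Cl)C(N)=N1` share one core. In a functional assay on HCT-116 cells (Homo sapiens) for antiproliferative activity, read by MTT assay, with a stated time of 72 h (a higher number here means a weaker inhibitor, a lower number a stronger inhibitor), compound 1 gives 1 nM, and compound 2 gives 1 nM. The change between them, (chloro in place of hydrogen on an aromatic carbon), leaves the measurement where it was: no change at the digits printed from compound 1 to compound 2 (within the scatter). Compound 3 `NC1=NC2(CCOCC2)N(OCCCOc2ccc(Cl)c(Cl)c2)C(N)=N1` has a different core; the difference between the two cores is not broken down here. In this assay compound 3 gives 90 nM. Compound 4 `NC1=NC2(CCOCC2)N(OCCCOc2cc(Cl)c(Cl)cc2Cl)C(N)=N1`, which is not yet measured, carries the same change on the core of compound 3, namely (chloro in place of hydrogen on an aromatic carbon). Among the compounds with values here, the step from compound 3 to compound 4 is expected to be of like size, no change at the digits printed from compound 3 to compound 4 (within the scatter), because no change at the digits printed from compound 1 to compound 2 (within the scatter) is the one measured instance of this change. Compound 4 is therefore estimated at 90 nM in this assay, with a range from 30 nM to 270 nM.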

Compound 4, half-maximal inhibitory concentration: 2750 nM
Estimate against measurement, compound 4: 31-fold (1.49 log units) below, and the stated range ends below it.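

In this assay, the change from 3,4-dichlorophenyl to 2,4,5-trichlorophenyl behaves differently on the core of compound 3, where the step is a 31-fold higher number from compound 3 to compound 4 (1.49 log units; beyond the scatter). Set beside the earlier step, the two results clearly differ: the same change on two cores in this assay, no change at the digits printed (within the scatter) from compound 1 to compound 2 and a 31-fold higher number (1.49 log units; beyond the scatter) from compound 3 to compound 4, 31-fold (1.49 log units) apart, beyond the scatter of two such steps. This shows that, in this series, the outcome of this change on one core cannot be carried over to the other, but it rests on a single pair of steps and does not show what in the cores underlies the difference.

The compounds shown leave open how a fluoro or a methoxy group on the aromatic ring would behave on these two cores. They also leave open whether a longer chain would alter the gap between the two steps.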